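Ester side-chain change in a dienoate series

The source may hold more compounds than are shown below. What is called first, only, known or untested is meant among the compounds shown, and "the series" means these compounds.

Compound 2 `COC(C)(C)CCCC(C)C/C=C/C(C)=C/C(=O)OCCC(C)C` is the lower of the two measured entries in a physicochemical assay for lipophilicity; a higher number here means a more lipophilic compound, a lower number a more polar compound: in this assay compound 2 gives 7.03. Going by the values given here, the other measured entry, compound 1 `CCC(C)OC(=O)/C=C(C)/C=C/CC(C)CCCC(C)C`, gives 7.69 in this assay, a number higher than that of compound 2 by more than the usual scatter; the two differ at several places, so no single step joins them. Compound 3 `COC(C)(C)CCCC(C)C/C=C/C(C)=C/C(=O)OC1CCCC1` has not yet been measured. It differs from compound 2 in one place: cyclopentyl in place of isopentyl on an oxygen next to a carbonyl group. Among the compounds with values here, no measured pair shows this change, so its size is unknown here. Expected is a small step downward, close to the edge of the scatter, a number 0.33 log units lower from compound 2 to compound 3 (beyond the scatter). For compound 3 the partition coefficient is estimated at 6.7, with a range from 6.3 to 7.1.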

Compound 3, partition coefficient: 7.01
Estimate against measurement, compound 3: 0.31 log units below; the range from low to high includes it.
By their numbers in this assay, from the lowest: compounds 3 and 2 (each within the scatter of the next); then compound 1.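

This position now has its first readable step: in this assay, cyclopentyl in place of isopentyl on an oxygen next to a carbonyl group gives a number 0.02 log units lower from compound 2 to compound 3 (within the scatter) and leaves the two compounds level. Within this pair, therefore, a five-membered ring in place of an open chain, at the same 5 heavy atoms and with no hydrogen-bond donors or acceptors on either side, makes no difference that this read-out can resolve. Nothing at hand gives a reason for this result.

Going by these compounds, this rests on a single pair, so it remains open whether a longer chain, a phenyl ring or an amine on this oxygen would also leave the number in place. Also open, on these data alone, is whether the same change would read alike on the core of compound 1, which differs from compound 2 at several places.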